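The source may hold more compounds than are shown below. What is called first, only, known or untested is meant among the compounds shown, and "the series" means these compounds.

Of the compounds shown here, two have been measured so far. In a functional assay on SW-620 cells (Homo sapiens) for cytotoxicity, read by MTT assay, with a stated time of 72 h (a higher number here means a weaker inhibitor, a lower number a stronger inhibitor), compound 1 `COc1cccc(/C=C2\CCC/C(=C\c3ccc(Cl)c(Cl)c3)C2=O)c1OC` gives 10000 nM and compound 2 `COc1ccc(/C=C2\CCC/C(=C\c3ccccc3Br)C2=O)cc1OC` gives 5300 nM so these two values lie within the scatter of each other. Compound 2 therefore stands level with compound 1 on the numbers available.

Compound 3 `COc1ccc(/C=C2\CCC/C(=C\c3cccc(O)c3)C2=O)cc1OC` has not yet been measured in this assay and differs from compound 2 in one place. It carries 3-hydroxyphenyl in place of 2-bromophenyl on a double-bonded chain carbon bound to a double-bonded ring carbon and the rest of the structure is unchanged.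

Within the data shown here, the series offers no measured pair that differs in one place only, so there is no direct precedent for this change. Compound 1 and compound 2 differ in more than one place, yet their values stay within the scatter. No step beyond the scatter is therefore expected. The estimated 1.3-fold lower number from compound 2 to compound 3 (0.12 log units; within the scatter) in this assay leans slightly toward a lower number. For compound 3 the expected value is 4000 nM with an estimated range from 1300 nM to 12000 nM for a single measurement.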

Compound 3, half-maximal inhibitory concentration: 1900 nM
Beside the measured number, compound 3's estimate is 2.1-fold (0.32 log units) above it, and the stated range covers the measured number.
By their numbers in this assay, from the lowest: compound 3; then compounds 2 and 1 (each within the scatter of the next).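

Among these compounds, this is the first measured step that changes one place only. With the rest of the structure unchanged, 3-hydroxyphenyl in place of 2-bromophenyl on a double-bonded chain carbon bound to a double-bonded ring carbon gives a 2.8-fold lower number from compound 2 to compound 3 (0.45 log units; beyond the scatter) in this assay and so shows that the group at this position can move the number beyond the scatter, which compound 1 and compound 2, differing in more than one place, could not show. The change replaces bromine with oxygen and brings 1 hydrogen-bond donor and 1 hydrogen-bond acceptor where 2-bromophenyl has 0 of each, but no supporting measurement connects the step to any one of these differences.

Among the compounds shown here, the single step leaves the loss of the bromine and the gain of the hydroxyl unseparated, and it does not show whether the place of the substituent on the aromatic ring matters. An amine or a carboxylic acid in place of the hydroxyl of 3-hydroxyphenyl remains an open case, as does the size of the same change on the core of compound 1.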